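Replacing a benzothiazole with an aryl urea: solubility outlook

This account rests on a few compounds, and the source may have more. Where it says the series, first, only, none or still open, it means among the compounds named here.

For the measured compounds named here, compound 1 `CC(C)[C@H](NC(=O)c1cc(-c2ccc(Nc3nc4ccc(F)cc4s3)cc2)no1)C(=O)O` gives the lower of the two numbers known so far in a physicochemical assay for solubility, with a stated time of 24 h, at pH 7.4 (on this read-out lower numbers stand for lower solubility and higher numbers for higher solubility), at 60 ug/mL. Compound 2 `CC(C)[C@H](NC(=O)c1cc(-c2ccc(NC(=O)Nc3ccc(Cl)cc3Oc3ccccc3)cc2)no1)C(=O)O`, which carries an aryl urea in the same region, gives 140 ug/mL, a gap beyond the usual scatter. Compound 3 `Cc1ccc(NC(=O)Nc2ccc(-c3cc(C(=O)N[C@H](C(=O)O)C(C)C)on3)cc2)cc1` differs from compound 1 by (4-methylphenyl)carbamoyl in place of 6-fluoro-1,3-benzothiazol-2-yl on a nitrogen on an aromatic ring. Since compound 3 also carries an aryl urea on that nitrogen, a modest upward step a 2.0-fold higher number from compound 1 to compound 3 (0.30 log units; within the scatter) is expected, because compound 2 gives 140 ug/mL. Compound 3 is therefore estimated at 120 ug/mL, within a range from 50 ug/mL to 300 ug/mL in this assay.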

Compound 3, solubility: 380 ug/mL
Beside the measured number, compound 3's estimate is 3.2-fold (0.50 log units) below it, outside the stated range (above it).
By their numbers in this assay, from the lowest: compound 1; then compound 2; then compound 3.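

On a nitrogen on an aromatic ring, (4-methylphenyl)carbamoyl in place of 6-fluoro-1,3-benzothiazol-2-yl gives in this assay a 6.3-fold higher number from compound 1 to compound 3 (0.80 log units; beyond the scatter). For the compounds shown here, this is the first reading of this position through a change in one place, and both groups have the same count of heavy atoms. Nothing measured here accounts for the step.

On these data alone, whether the step follows the carbamoyl part or the 4-methylphenyl ring stays open. As far as these compounds go, it is also open whether an amine or a longer chain on that ring would keep the higher number.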